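The compounds below may be only part of what the source reports. "The series", "measured", "known", "first", "only" and "open" are said of these compounds alone.

Working notes on the series: in a functional assay on FM3A cells (Mus musculus) for antiproliferative activity (a lower number here means a stronger inhibitor, a higher number a weaker inhibitor), compound 1 (`COc1cc(C(=O)c2sc(-c3ccc(Br)cc3)cc2N)cc(OC)c1OC`) gives 150 nM, compound 2 (`COc1cc(C(=O)c2sc(-c3ccc([N+](=O)[O-])cc3)cc2N)cc(OC)c1OC`) gives 64 nM, and compound 3 (`COc1cc(C(=O)c2sc(-c3ccc(Cl)c(Cl)c3)cc2N)cc(OC)c1OC`) gives 400 nM, the highest of the three numbers. Compound 4 (`COc1cc(C(=O)c2sc(-c3ccsc3)cc2N)cc(OC)c1OC`) carries thiophen-3-yl in place of 3,4-dichlorophenyl on an aromatic carbon. The nearest evidence is the two steps that introduce 3,4-dichlorophenyl, a 2.7-fold higher number from compound 1 to compound 3 (0.43 log units; beyond the scatter) and a 6.3-fold higher number from compound 2 to compound 3 (0.80 log units; beyond the scatter), both modest but beyond the scatter. The step of a 2.3-fold lower number from compound 1 to compound 2 (0.37 log units; beyond the scatter) shows a similar range among the other aryl groups. Within the data shown here, no measured compound carries thiophen-3-yl, so a modest reversal towards lower numbers in this assay is only an expectation. The expected change is a 2.7-fold lower number from compound 3 to compound 4 (0.43 log units; beyond the scatter). For compound 4 the estimate is 150 nM, with an expected range of 50 nM to 450 nM.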

Compound 4, half-maximal inhibitory concentration: 3.7 nM
The estimate for compound 4 lay 41-fold (1.61 log units) above the measured number; measured number outside the range, below it.
By their numbers in this assay, from the lowest: compound 4; then compound 2; then compound 1; then compound 3.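

In this assay thiophen-3-yl gives a 110-fold lower number from compound 3 to compound 4 (2.03 log units; beyond the scatter) and also a 17-fold lower number from compound 2 to compound 4 (1.24 log units; beyond the scatter) and a 41-fold lower number from compound 1 to compound 4 (1.61 log units; beyond the scatter). All three steps are large, whereas the steps among the three substituted phenyl groups were modest, so this place on the shared core responds far more to exchanging the phenyl for a five-membered aromatic ring with sulfur than to changing the phenyl substituent. Nothing available explains the size of this change.

From the compounds shown here alone, it remains open whether the low number is specific to thiophen-3-yl or is shared by thiophen-2-yl, furan-3-yl or unsubstituted phenyl at this place.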